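The compounds below may be only part of what the source reports. "The series", "measured", "known", "first", "only" and "open" are said of these compounds alone.

Within the data shown here, compound 2 `Cn1ncc(Cl)c1-c1cc(C(=O)N[C@@H]2CN[C@H](CC(=O)NC3CC3)C[C@H]2c2ccc(Cl)c(Cl)c2)oc1Cl` gives 190 nM in a functional assay on LNCaP cells (Homo sapiens) for antiproliferative activity (a higher number here means a weaker inhibitor, a lower number a stronger inhibitor), the highest of the three numbers known so far. Compound 1 `Cn1ncc(Cl)c1-c1cc(C(=O)N[C@@H]2CN[C@H](CCn3cncn3)C[C@H]2c2ccc(Cl)c(Cl)c2)oc1Cl` gives 60 nM, and compound 3 `CNC(=O)C[C@@H]1C[C@@H](c2ccc(F)c(F)c2)[C@H](NC(=O)c2cc(-c3c(Cl)cnn3C)c(Cl)o2)CN1` gives 50 nM. Compound 4 `Cn1ncc(Cl)c1-c1cc(C(=O)N[C@@H]2CN[C@H](CC(=O)NCC(O)CO)C[C@H]2c2ccc(Cl)c(Cl)c2)oc1Cl` differs from compound 2 in one place: 2,3-dihydroxypropyl in place of cyclopropyl on an amide-type nitrogen. Among the measured compounds shown here, the only measured single-place step, a 3.2-fold higher number from compound 1 to compound 2 (0.50 log units; beyond the scatter), alters the chain before the amide rather than the group on the amide nitrogen, so it bears on this change only loosely. Compound 3 differs from compound 2 in more than one place, so its lower number offers no clean guide either. Compound 4 is therefore expected to stay near compound 2, at an estimated 160 nM with a range of 60 nM to 450 nM. The expected step is a 1.2-fold lower number from compound 2 to compound 4 (0.07 log units; within the scatter), within the scatter.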

Compound 4, half-maximal inhibitory concentration: 660 nM
Compound 4: middle estimate off by 4.1-fold (0.62 log units), on the low side; measured number above the stated range.
By their numbers in this assay, from the lowest: compounds 3 and 1 (each within the scatter of the next); then compound 2; then compound 4.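

In this assay, the group on the amide-type nitrogen clearly matters: 2,3-dihydroxypropyl in place of cyclopropyl gives a 3.5-fold higher number from compound 2 to compound 4 (0.54 log units; beyond the scatter). Replacing (1H-1,2,4-triazol-1-yl)methyl with the whole (2,3-dihydroxypropyl)carbamoyl group gives a large change, an 11-fold higher number from compound 1 to compound 4 (1.04 log units; beyond the scatter). No measurement here explains either step.

The compounds shown leave open whether the higher number goes with losing the cyclopropyl ring or with gaining the hydroxy groups. A plain propyl chain on the same nitrogen would separate these two changes.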